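Replacing 1H-pyrrol-2-yl with 2-methoxyphenyl: notes on the series

This account rests on a few compounds, and the source may have more. Where it says the series, first, only, none or still open, it means among the compounds named here.

Of the compounds shown here, three have values so far in a functional assay on DU-145 cells (Homo sapiens) for inhibition, read by trypan blue exclusion, with a stated time of 96 h; on this read-out higher numbers stand for weaker inhibition of growth and lower numbers for stronger inhibition of growth. Compound 1 (`Cc1ccc(S/C(=C/c2cc(Cl)cc(Cl)c2Cl)C(=O)c2ccc(Cl)cc2)cc1`) gives 50000 nM. Compound 2 (`COc1ccccc1/C=C(/Sc1ccc(C)cc1)C(=O)c1ccc(Br)cc1`) gives 9000 nM. Compound 3 (`Cc1ccc(S/C(=C/c2ccc[nH]2)C(=O)c2ccc(Cl)cc2)cc1`) gives 10000 nM. Compound 3 thus sits within the scatter of compound 2, and both numbers are well short of the number for compound 1.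

The next change leads to compound 4 (`COc1ccccc1/C=C(/Sc1ccc(C)cc1)C(=O)c1ccc(Cl)cc1`), with 2-methoxyphenyl in place of 1H-pyrrol-2-yl on a double-bonded chain carbon bound to a double-bonded chain carbon.

Within the data shown here, only one measured step touches this place: a 5.0-fold lower number from compound 1 to compound 3 (0.70 log units; beyond the scatter), a modest change beyond the scatter, with 1H-pyrrol-2-yl in place of 2,3,5-trichlorophenyl. That step does not involve 2-methoxyphenyl, so it gives only a loose guide to the size of change possible here. The closer reference carries 2-methoxyphenyl at the same place and differs from compound 4 elsewhere: it is compound 2, which gives 9000 nM. No step beyond the scatter is therefore expected in this assay. The expected step is a 1.1-fold lower number from compound 3 to compound 4 (0.05 log units; within the scatter), within the scatter. For compound 4 the estimated value is 9000 nM, with an expected range from 4000 nM to 20000 nM.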

Compound 4, concentration for 50% growth inhibition: 25000 nM
The estimate for compound 4 lay 2.8-fold (0.44 log units) below the measured number; the whole stated range lies below it.
By their numbers in this assay, from the lowest: compounds 2 and 3 (each within the scatter of the next); then compounds 4 and 1 (each within the scatter of the next).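

In this assay, 2-methoxyphenyl in place of 1H-pyrrol-2-yl on a double-bonded chain carbon bound to a double-bonded chain carbon gives a 2.5-fold higher number from compound 3 to compound 4 (0.40 log units; beyond the scatter), so the change has a measurable cost at this position, whereas 2-methoxyphenyl in place of 2,3,5-trichlorophenyl gives a 2.0-fold lower number from compound 1 to compound 4 (0.30 log units; within the scatter), which leaves those two groups unseparated. The value for the bromo compound also does not carry over to its chloro counterpart: chloro in place of bromo on an aromatic carbon gives a 2.8-fold higher number from compound 2 to compound 4 (0.44 log units; beyond the scatter), so in this pair the halogen is a second place that moves the number beyond the scatter, and 2-methoxyphenyl alone does not fix the value. No available evidence bears on the origin of either step.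

Still open is whether the chloro-for-bromo step holds with 1H-pyrrol-2-yl or 2,3,5-trichlorophenyl on the chain carbon, since the compounds shown test it only with 2-methoxyphenyl. Also open, from the compounds shown here alone, is what an amine or a carboxylic acid would give at that same chain carbon, with the rest of the core held.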